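Notes on replacing anilino with amino in compound 2

The source may hold more compounds than are shown below. What is called first, only, known or untested is meant among the compounds shown, and "the series" means these compounds.

- compound 1 `NC(=S)N/N=C/c1ccccc1O`: >= 5000 nM, a limit of the assay
- compound 2 `COc1cccc(/C=N/NC(=S)Nc2ccccc2)c1O`: 1400 nM

Among the measured compounds shown here, in a functional assay on WI-38 cells (Homo sapiens) for antiproliferative activity, read by MTT assay, with a stated time of 72 h (on this read-out higher numbers stand for weaker inhibition and lower numbers for stronger inhibition), compound 2 stands at 1400 nM, the only true number so far. Compound 3 `COc1cccc(/C=N/NC(N)=S)c1O` differs from compound 2 by hydrogen in place of phenyl on an amide-type nitrogen. Compound 1, which also carries the amino group, is the ground for expecting weaker inhibition: it reads >= 5000 nM, a limit. The expected change in this assay is a 3.6-fold higher number from compound 2 to compound 3 (0.55 log units; beyond the scatter), a move to weaker inhibition beyond the scatter. The estimate for compound 3 is 5000 nM, with an expected range of 2000 nM to 12000 nM.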

Compound 3, half-maximal inhibitory concentration: 300 nM
For compound 3 the middle estimate is 17-fold (1.22 log units) above the measured one; the whole stated range lies above it.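

In this assay the phenyl on the amide-type nitrogen is not required for inhibition, with a 4.7-fold lower number from compound 2 to compound 3 (0.67 log units; beyond the scatter) when hydrogen replaces it. With the amino group held, methoxy in place of hydrogen on an aromatic carbon gives an at least 16-fold lower number from compound 1 to compound 3 (1.22 log units; beyond the scatter) and separates the two amino compounds. Compound 1 stands at a limit of the assay, not at a number: the limit of >= 5000 nM in this assay, at which 1 of the 3 values shown sits.

As far as these compounds go, whether a methyl or an ethyl group on that nitrogen keeps the lower number stays open. So does whether ethoxy or a chlorine atom can stand in for the methoxy group.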